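A fluoro swap on the chain of compound 2

The compounds below may be only part of what the source reports. "The series", "measured", "known", "first", "only" and "open" are said of these compounds alone.

- compound 1 `COc1cc(C(c2ccc(O)c(OC)c2)[C@@H](C)[C@@H](C)CO)ccc1O`: > 100000 nM (a limit of the assay, not a number)
- compound 2 `COc1cc(C(c2ccc(O)c(OC)c2)[C@H](C)C(C)C)ccc1O`: 17000 nM
- compound 3 `COC[C@H](C)[C@@H](C)C(c1ccc(O)c(OC)c1)c1ccc(O)c(OC)c1`: 68000 nM
- compound 4 `COc1cc(C(c2ccc(O)c(OC)c2)[C@H](CF)C(C)C)ccc1O`: not yet measured

These values come from a functional assay on HL-60 cells (Homo sapiens) for cytotoxicity, read by WST assay, with a stated time of 48 h; on this read-out lower numbers stand for stronger inhibition and higher numbers for weaker inhibition. Only two of the three results are true numbers, and compound 2 has the lower of them, at 17000 nM. The value for compound 1 is only a limit.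

Compound 4 differs from compound 2 by a single change: fluoro in place of hydrogen on a saturated chain carbon, three bonds along the chain from two aromatic carbons. Put simply, this is fluoro in place of hydrogen, turning methyl into fluoromethyl.

The closest guides are two measured steps at a different place, four bonds along the chain. One is a 4.0-fold higher number from compound 2 to compound 3 (0.60 log units; beyond the scatter). The other, which ends at compound 2, is an at least 5.8-fold lower number from compound 1 to compound 2 (0.76 log units; beyond the scatter). In both, the compound with hydrogen at that place has the lower number. Since the new change sits elsewhere and adds only one fluorine, a small upward shift is expected, no larger than the methoxy step to compound 3 at 68000 nM.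

The expected step is a 1.5-fold higher number from compound 2 to compound 4 (0.18 log units; within the scatter). The estimate for compound 4 is 26000 nM, with an expected range of 9000 nM to 75000 nM.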

Compound 4, half-maximal inhibitory concentration: 19000 nM
For compound 4 the middle estimate is 1.4-fold (0.14 log units) above the measured one; the range from low to high includes it.
By their numbers in this assay, from the lowest: compounds 2 and 4 (each within the scatter of the next); then compound 3. At a limit, above all of these: compound 1.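

Swapping hydrogen for fluoro at this place, turning methyl into fluoromethyl, gives a number in this assay that cannot be told apart from that of the parent, with a 1.1-fold higher number from compound 2 to compound 4 (0.05 log units; within the scatter). Among the compounds shown here, the earlier steps all changed the chain four bonds along from the two aromatic carbons, so this is the first sign that a fluoro three bonds along keeps the parent's level, and the fluoromethyl compound also stays clear of the methoxy compound, with a 3.6-fold lower number from compound 3 to compound 4 (0.55 log units; beyond the scatter). Compound 1 is held only at a limit, so an at least 5.2-fold lower number from compound 1 to compound 4 (0.72 log units; beyond the scatter) is a floor and not a measured gap: the limit of > 100000 nM in this assay, at which 1 of the 4 values shown sits.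

From the compounds shown here alone, whether this place also accepts something larger than fluoromethyl, such as trifluoromethyl, an aminomethyl group or a longer chain, stays open. Going by these compounds, it is also open whether a fluoro four bonds along the chain would behave like the one here.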